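This account rests on a few compounds, and the source may have more. Where it says the series, first, only, none or still open, it means among the compounds named here.

In a functional assay on HL-60 cells (Homo sapiens) for inhibition, read by CCK-8 assay, with a stated time of 48 h, tested at 20 uM (a lower number here means less inhibition of growth, a higher number more inhibition of growth at the concentration tested), the measured compounds read:

compound 1 `N#C/C(=C\c1ccccc1OS(=O)(=O)c1ccccc1[N+](=O)[O-])C(=O)Nc1nnc(Cc2ccccc2)s1` gives 12%;
compound 2 `N#C/C(=C\c1ccccc1OS(=O)(=O)c1ccc(Cl)cc1)C(=O)Nc1nnc(Cc2ccccc2)s1` gives 26%;
compound 3 `N#C/C(=C\c1ccccc1OS(=O)(=O)c1ccccc1[N+](=O)[O-])C(=O)Nc1nnc(Cc2ccc(F)cc2)s1` gives 35%.

One change recurs twice here. Between compound 1 and compound 2 it is 4-chlorophenyl in place of 2-nitrophenyl on a sulfonyl sulfur, and it made a number 14 percentage points higher from compound 1 to compound 2 (beyond the scatter). Compound 4 `N#C/C(=C\c1ccccc1OS(=O)(=O)c1ccc(Cl)cc1)C(=O)Nc1nnc(Cc2ccc(F)cc2)s1` carries the same change relative to compound 3, written as 4-chlorophenyl in place of 2-nitrophenyl on a sulfonyl sulfur; the place around it is the same in both pairs. The two cores differ by fluoro in place of hydrogen on an aromatic carbon, which made a number 23 percentage points higher from compound 1 to compound 3 (beyond the scatter). Because the first pair gave a number 14 percentage points higher from compound 1 to compound 2 (beyond the scatter), a step of about that size is expected again, a number 12 percentage points higher from compound 3 to compound 4 (beyond the scatter), beside the earlier one, though a single prior pair is a thin basis. Compound 4 is therefore estimated at 47% in this assay, with a likely range from 28% to 66%.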

Compound 4, percent growth inhibition at one concentration: 20%
Beside the measured number, compound 4's estimate is 27 percentage points above it; the whole stated range lies above it.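

In this assay, 4-chlorophenyl in place of 2-nitrophenyl on the sulfonyl sulfur gave a number 15 percentage points lower from compound 3 to compound 4 (beyond the scatter), so the step did not carry over to the fluoro-bearing core: the same change on two cores in this assay, a number 14 percentage points higher (beyond the scatter) from compound 1 to compound 2 and a number 15 percentage points lower (beyond the scatter) from compound 3 to compound 4, 29 percentage points apart, beyond the scatter of two such steps. With 4-chlorophenyl in place, fluoro in place of hydrogen gave a number 6 percentage points lower from compound 2 to compound 4 (within the scatter), which also differs from its step with 2-nitrophenyl: the same change on two cores in this assay, a number 23 percentage points higher (beyond the scatter) from compound 1 to compound 3 and a number 6 percentage points lower (within the scatter) from compound 2 to compound 4, 29 percentage points apart, beyond the scatter of two such steps. In these four compounds, the result of each change depends on the other group present, but the numbers do not show why, nor whether this holds elsewhere in the series.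

As far as these compounds go, it remains open how a plain phenyl or a 4-methoxyphenyl on the sulfonyl sulfur would behave. From the compounds shown here alone, the effect of a chloro or a methoxy in place of the fluoro is also open.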